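Removing a methoxy group from a dimethoxypyridinyl sulfonylurea

The compounds below may be only part of what the source reports. "The series", "measured", "known", "first", "only" and "open" are said of these compounds alone.

Measured compounds:
compound 1, `COc1cc(F)c(CN2C(=O)N(c3ccc(OC)c(OC)c3)S(=O)(=O)c3ccccc32)c(Cl)c1`, 0.1 nM;
compound 2, `COc1ccc(N2C(=O)N(Cc3c(F)cccc3Cl)c3ccccc3S2(=O)=O)cc1OC`, 0.794 nM;
compound 3, `COc1cc(N2C(=O)N(Cc3c(F)cc(F)cc3F)c3ccccc3S2(=O)=O)cc(OC)n1`, 1.26 nM.

In an assay on HEK293 cells for displacement of a labelled ligand from Orexin receptor type 2 (Homo sapiens), read by scintillation counting, with a stated time of 90 min (a lower number here means a stronger inhibitor, a higher number a weaker inhibitor), compound 1 gives 0.1 nM, and compound 2 gives 0.794 nM. The change between them, (hydrogen in place of methoxy on an aromatic carbon), made a 7.9-fold higher number from compound 1 to compound 2 (0.90 log units; beyond the scatter). Compound 3 gives 1.26 nM in this assay; its difference from compound 1 is not broken down here. Compound 4, `COc1cc(N2C(=O)N(Cc3c(F)cc(F)cc3F)c3ccccc3S2(=O)=O)ccn1`, is not yet measured and differs from compound 3 by hydrogen in place of methoxy on an aromatic carbon. This is the same kind of change as from compound 1 to compound 2, but at a different place: on a six-membered aromatic ring with 1 nitrogen, next to the ring nitrogen, meta to a large group and meta to a methoxy group, rather than on a ring of carbon only, meta to a chloro and a fluoro group and para to a large group. Because a 7.9-fold higher number from compound 1 to compound 2 (0.90 log units; beyond the scatter) shows a loss, compound 4 is expected to be weaker than compound 3, by a 4.0-fold higher number from compound 3 to compound 4 (0.60 log units; beyond the scatter), with the different place leaving the size uncertain. Compound 4 is estimated at 5 nM, between 1.5 nM and 20 nM.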

Compound 4, inhibition constant: 63.1 nM
Estimate against measurement, compound 4: 13-fold (1.10 log units) below; measured number outside the range, above it.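

In this assay the change from 2,6-dimethoxypyridin-4-yl to 2-methoxypyridin-4-yl gave a 50-fold higher number from compound 3 to compound 4 (1.70 log units; beyond the scatter), a loss in the same direction as the earlier step. The direction carried from one core to the other, but the size did not: the same change on two cores in this assay, a 7.9-fold higher number (0.90 log units; beyond the scatter) from compound 1 to compound 2 and a 50-fold higher number (1.70 log units; beyond the scatter) from compound 3 to compound 4, 6.3-fold (0.80 log units) apart, beyond the scatter of two such steps. The two pairs differ both in the ring that carries the methoxy group and elsewhere in their structures, so these compounds do not show which difference accounts for the gap, and two pairs give no general rule for the series.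

Going by these compounds, whether an amine or an ethoxy group in that place would match compound 3 remains open. So does the outcome of replacing the remaining methoxy group of compound 4.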